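A few compounds are considered here, and "the series" means these few. Any claim that something is new, unique, unknown or untested is made for them only; others in the source may bear on it.

Of the compounds shown here, three built on one shared core have been measured in a functional assay on OVCAR-4 cells (Homo sapiens) for inhibition, read by sulforhodamine B assay, with a stated time of 48 h, tested at 10 uM; a lower number here means less inhibition, a higher number more inhibition at the concentration tested (going by the name of the read-out). Compound 1 `Brc1cn2ccnc2c(-c2ccc3ncn(C4CCCCC4)c3c2)n1` gives 9.15%, compound 2 `Clc1ccc(-c2cn3ccnc3c(-c3ccc4ncn(C5CCCCC5)c4c3)n2)cc1` gives 4.57%, and compound 3 `Brc1ccc(-c2cn3ccnc3c(-c3ccc4ncn(C5CCCCC5)c4c3)n2)cc1` gives 10.5%. Compound 3 holds the highest of the three numbers, yet it does not stand apart, since its steps to compound 1 and to compound 2 both lie within the scatter. The next compound, compound 4 `COc1ccccc1-c1cn2ccnc2c(-c2ccc3ncn(C4CCCCC4)c3c2)n1`, differs from compound 3 in one place: 2-methoxyphenyl in place of 4-bromophenyl on an aromatic carbon, the group sitting meta to a fused ring and para to a fused ring on the core. The measured steps that touch this position are a number 1.4 percentage points higher from compound 1 to compound 3 (within the scatter) and a number 5.9 percentage points higher from compound 2 to compound 3 (within the scatter); neither moved this assay beyond the scatter. Going by the values given here, no measured step brings in a methoxy group, so the expectation rests only on the flatness seen so far. Compound 4 is therefore expected to stay near its neighbours, the expected step being a number 2.5 percentage points lower from compound 3 to compound 4 (within the scatter) in this assay. The estimate for compound 4 is 8%, within a range from 0% to 22%.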

Compound 4, a percentage reported as inhibition, at one concentration (the size of the read-out at that concentration, not a potency): 13.2%
Compound 4: the middle estimate sits 5.2 percentage points below what was measured; the range from low to high includes it.
By their numbers in this assay, from the lowest: compounds 2, 1, 3 and 4 (each within the scatter of the next).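

In this assay, the step to a group with an oxygen, which earlier occupants of this position lacked, is a number 2.7 percentage points higher from compound 3 to compound 4 (within the scatter) when 2-methoxyphenyl replaces 4-bromophenyl and a number 8.6 percentage points higher from compound 2 to compound 4 (within the scatter) when it replaces 4-chlorophenyl. Set against the plain bromo, the change is a number 4.1 percentage points higher from compound 1 to compound 4 (within the scatter). So the flatness seen among the bromo, 4-chlorophenyl and 4-bromophenyl compounds also holds for a methoxy-bearing aryl group with a hydrogen-bond acceptor, and the data offer no explanation for these small differences.

As far as these compounds go, whether any group on this aromatic carbon can carry the number beyond the scatter remains open. An amine, a carboxylic acid or a longer alkyl chain here could answer that, as could a pyridine ring in place of the phenyl.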